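The source may report more compounds than this note shows. Statements on the series, on what has been measured and on what is new or still open speak of the compounds shown alone.

Measured so far:
- compound 1, `COC(=O)c1c(Nc2ccc(OC)cc2)sc(C(=O)c2ccc(OC)cc2)c1C`, 5.9%
- compound 2, `COC(=O)c1c(Nc2ccc(F)cc2)sc(C(=O)c2ccc(OC)cc2)c1C`, 14%
- compound 3, `COc1ccc(Nc2sc(C(=O)c3ccc(OC)cc3)c(C)c2C(=O)O)cc1`, 23.5%

In a functional assay, with a stated time of 150 min, tested at 10 ug/mL (a higher number here means a stronger effect of the compound at the concentration tested, a lower number a weaker effect), compound 1 gives 5.9%. The step of a number 8.1 percentage points higher from compound 1 to compound 2 (within the scatter) comes from the change (fluoro in place of methoxy on an aromatic carbon). The second change from compound 1, (hydrogen in place of methyl on an oxygen next to a carbonyl group), gives a number 17.6 percentage points higher from compound 1 to compound 3 (beyond the scatter); in this assay compound 3 gives 23.5%, and compound 2 gives 14%, the two lying within the scatter of each other.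

Compound 4, `COc1ccc(C(=O)c2sc(Nc3ccc(F)cc3)c(C(=O)O)c2C)cc1`, is not yet measured. It relates to compound 3 by fluoro in place of methoxy on an aromatic carbon, which is the same change made from compound 1 to compound 2, at the same place. The two cores differ by hydrogen in place of methyl on an oxygen next to a carbonyl group. Among the compounds with values here, with only one earlier example of the change, the expectation rests on that step alone: a step of about the same size as a number 8.1 percentage points higher from compound 1 to compound 2 (within the scatter) is expected, so for compound 4 the step of a number 6.5 percentage points higher from compound 3 to compound 4 (within the scatter) is estimated, which would remain within the scatter of compound 3. Compound 4 is thus expected to give about 30% in this assay, with a range from 16% to 44%.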

Compound 4, a percentage reported as activity, at one concentration (the size of the read-out at that concentration, not a potency): 0.98%
Compound 4: the middle estimate sits 29 percentage points above what was measured, and the stated range ends above it.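

In this assay, fluoro in place of methoxy does not carry over from one core to the other, as the step of a number 22.5 percentage points lower from compound 3 to compound 4 (beyond the scatter) differs from the earlier one: the same change on two cores in this assay, a number 8.1 percentage points higher (within the scatter) from compound 1 to compound 2 and a number 22.5 percentage points lower (beyond the scatter) from compound 3 to compound 4, 30.6 percentage points apart, beyond the scatter of two such steps. Hydrogen in place of methyl on the ester oxygen is just as dependent on its surroundings, since with the fluoro group in place the step is a number 13 percentage points lower from compound 2 to compound 4 (beyond the scatter), which also differs from the earlier one: the same change on two cores in this assay, a number 17.6 percentage points higher (beyond the scatter) from compound 1 to compound 3 and a number 13 percentage points lower (beyond the scatter) from compound 2 to compound 4, 30.6 percentage points apart, beyond the scatter of two such steps. This shows that the two changes do not add up across these four compounds, but it gives no cause, and as the earlier fluoro step lies within the scatter, the contrast rests on the gap between the steps and not on two firm opposite directions.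

The compounds shown leave open whether another group in place of the methoxy, such as chloro, methyl or an amine, would behave as fluoro does. They also leave open whether an amide or a nitrile in place of the carboxylic acid would show the same dependence.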